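Shifting Two Fluorines: What Compound 4 Might Show

The source may hold more compounds than are shown below. What is called first, only, known or untested is meant among the compounds shown, and "the series" means these compounds.

Three compounds of one series have been examined in an ADME assay on MRC5 cells (Homo sapiens) for inhibition, with a stated time of 72 h; on this read-out higher numbers stand for an effect only at larger amounts of compound and lower numbers for an effect already at smaller amounts. Compound 1 `COc1cccc(OC)c1C(=O)Nc1c[nH]nc1C(=O)Nc1ccncc1` reaches only the limit of > 50000 nM in this assay. Compound 3 `COc1cccc(OC)c1C(=O)Nc1c[nH]nc1C(=O)NC1CCN(C(=O)OC(C)(C)C)CC1` likewise gives only the limit of > 50000 nM. Going by the values given here, compound 2 `CO[C@H]1CC[C@H](NC(=O)c2n[nH]cc2NC(=O)c2ccc(F)cc2F)CC1` is the sole member with a measured number, 11000 nM in this assay, so it stands apart from the limit of > 50000 nM in this assay, at which 2 of the 3 values shown sit. Among the compounds with values here, no two measured compounds differ in just one place, so no measured step is available. Compound 4 `CO[C@H]1CC[C@H](NC(=O)c2n[nH]cc2NC(=O)c2cc(F)cc(F)c2)CC1` is the next to be tested; it differs from compound 2 by 3,5-difluorophenyl in place of 2,4-difluorophenyl on a carbonyl carbon. Within the data shown here, with the same atoms joined differently and no measured step to lean on, the step from compound 2 to compound 4 is expected to stay within the scatter, a 1.1-fold higher number from compound 2 to compound 4 (0.04 log units; within the scatter). Compound 4 is therefore estimated at 12000 nM, between 4000 nM and 40000 nM.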

Compound 4, half-maximal effective concentration: 600 nM
Compound 4: the middle estimate sits 20-fold (1.30 log units) above what was measured; the whole stated range lies above it.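

In this assay, moving the two fluorines on the phenyl attached to the carbonyl carbon is enough to give an 18-fold lower number from compound 2 to compound 4 (1.26 log units; beyond the scatter). Going by these compounds alone, the earlier compounds offered no measured step, so this is the first sign that this position responds to a rearrangement of the same atoms alone. Nothing shown here accounts for the size of this step.

Still open is whether the fluorines themselves are needed, since a phenyl carrying chlorine, a nitrile or an amine in their place does not appear among these compounds.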